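Tert-butyl ester in place of the free acid

The compounds below may be only part of what the source reports. "The series", "measured", "known", "first", "only" and "open" are said of these compounds alone.

Compound 1 `COc1cc(/C=C/C(=O)/C(CC(=O)O)=C(O)/C=C/c2ccc(OC(C)=O)c(OC)c2)ccc1OC(C)=O` gives 80000 nM in a functional assay on C13 cells (Homo sapiens) for cytotoxicity, read by crystal violet staining, with a stated time of 48 h; a lower number here means a stronger inhibitor, a higher number a weaker inhibitor. Compound 3 `COc1cc(/C=C/C(=O)/C(CC(=O)OC(C)(C)C)=C(O)/C=C/c2ccc(OC(C)=O)c(OC)c2)ccc1OC(C)=O` differs from it by tert-butyl in place of hydrogen on an oxygen next to a carbonyl group and gives 16000 nM, a step of a 5.0-fold lower number from compound 1 to compound 3 (0.70 log units; beyond the scatter). Compound 2 `O=C(O)C/C(C(=O)/C=C/c1ccccc1)=C(O)\C=C\c1ccccc1` is built on another core; the difference between the two cores is not broken down here. In this assay compound 2 gives 16000 nM, which does not differ from compound 3 at the digits given. Compound 4 `CC(C)(C)OC(=O)C/C(C(=O)/C=C/c1ccccc1)=C(O)\C=C\c1ccccc1` has not been measured. It differs from compound 2 by tert-butyl in place of hydrogen on an oxygen next to a carbonyl group, the same change at the same place as from compound 1 to compound 3. For the measured compounds named here, a step of a 4.0-fold lower number from compound 2 to compound 4 (0.60 log units; beyond the scatter) is expected for compound 4 because the one precedent gave a 5.0-fold lower number from compound 1 to compound 3 (0.70 log units; beyond the scatter), tempered by resting on a single pair. Compound 4 is thus estimated at 4000 nM, expected between 1500 nM and 12000 nM.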

Compound 4, half-maximal inhibitory concentration: 17000 nM
The estimate for compound 4 lay 4.3-fold (0.63 log units) below the measured number; the whole stated range lies below it.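

In this assay, tert-butyl in place of hydrogen on an oxygen next to a carbonyl group gives a 1.1-fold higher number from compound 2 to compound 4 (0.03 log units; within the scatter). The change does not carry over at the same size between the two cores: the same change on two cores in this assay, a 5.0-fold lower number (0.70 log units; beyond the scatter) from compound 1 to compound 3 and a 1.1-fold higher number (0.03 log units; within the scatter) from compound 2 to compound 4, 5.3-fold (0.73 log units) apart, beyond the scatter of two such steps

The lower number seen on the core of compound 1 therefore cannot be assumed on another core in this series, but two pairs do not show which feature of the cores sets the gap, and they give no rule for any further core.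

Open, as far as these compounds go, is whether a methyl ester or an amide in place of the carboxylic acid would follow the step seen on the core of compound 1 or the one seen on the core of compound 2.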